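A few compounds are considered here, and "the series" means these few. Any claim that something is new, unique, unknown or untested is made for them only; others in the source may bear on it.

For the measured compounds named here, in a functional assay on Bel-7402 cells (Homo sapiens) for cytotoxicity, read by MTT assay, with a stated time of 72 h (on this read-out higher numbers stand for weaker inhibition and lower numbers for stronger inhibition), compound 1 `O=C(Nc1ccc(-n2ncc3c(Cl)cccc32)cc1)Nc1ccc(Cl)c(C(F)(F)F)c1` gives 2500 nM, the second highest of the three numbers measured so far. Compound 2 `O=C(Nc1ccc(-n2ncc3c(C(F)(F)F)cccc32)cc1)Nc1ccc(C(F)(F)F)cc1` gives 1000 nM, and compound 3 `O=C(Nc1ccc(-n2ncc3c(Cl)cccc32)cc1)Nc1ccc(C(F)(F)F)cc1` gives 8000 nM. Going by the values given here, the only single-point step among the measured compounds, an 8.0-fold higher number from compound 2 to compound 3 (0.90 log units; beyond the scatter), concerns the substituent on the bicyclic part of the shared core. Compound 4 `O=C(Nc1ccc(-n2ncc3cnccc32)cc1)Nc1ccc(Cl)c(C(F)(F)F)c1` changes that same part relative to compound 1: a group of 9 heavy atoms (6 carbon, 3 nitrogen; one five-membered aromatic ring with 2 hetero atoms, one six-membered aromatic ring with 1 hetero atom) in place of a group of 10 heavy atoms (7 carbon, 2 nitrogen, 1 chlorine; one five-membered aromatic ring with 2 hetero atoms, one six-membered aromatic ring of carbon only), on an aromatic carbon. Among the compounds with values here, no measured pair shows this exact exchange; the step from compound 2 to compound 3 indicates only that a change of one group on this part of the shared core can move the number in this assay well beyond the scatter. The change to compound 4 goes further than that step, so a real shift is expected, but its direction rests on little. The expected step of a 1.6-fold higher number from compound 1 to compound 4 (0.20 log units; within the scatter) is modest and upward, with the range kept wide. For compound 4 the estimated number in this assay is 4000 nM, expected to fall between 1000 nM and 16000 nM.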

Compound 4, half-maximal inhibitory concentration: 2700 nM
Compound 4: the middle estimate sits 1.5-fold (0.17 log units) above what was measured; low and high end bracket the measured number.
By their numbers in this assay, from the lowest: compound 2; then compounds 1 and 4 (each within the scatter of the next); then compound 3.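

In this assay, the group with a hetero atom in its six-membered aromatic ring and no chlorine, in place of 4-chloro-1H-indazol-1-yl, gives a 1.1-fold higher number from compound 1 to compound 4 (0.03 log units; within the scatter) and so no measurable change. For the compounds shown here, a change on this part of the shared core therefore does not always move the number, whereas the single exchange in an 8.0-fold higher number from compound 2 to compound 3 (0.90 log units; beyond the scatter) did so beyond the scatter. This exchange alters the ring and removes the chlorine at once, so the pair cannot show whether each change has little effect or whether the two offset each other.

No available measurement explains this result. Still open, on these data alone, are an amine or a carboxylic acid in place of the chlorine on the carbon-only ring, and the effect of the same exchange with the other end of the molecule as in compound 3.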